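A few compounds are considered here, and "the series" means these few. Any claim that something is new, unique, unknown or untested is made for them only; others in the source may bear on it.

Among the compounds with values here, compound 1 `COc1ccc(/C(Cl)=C/C=C(\C#N)C(=O)c2c(C)[nH]c3ccccc23)cc1` stands at the high end of the three numbers so far: in a functional assay on MCF7 cells (Homo sapiens) for cytotoxicity, read by sulforhodamine B assay, with a stated time of 48 h (on this read-out higher numbers stand for weaker inhibition of growth and lower numbers for stronger inhibition of growth), compound 1 gives 56700 nM. Compound 3 `COc1ccc(/C(Cl)=C/C=C(\C#N)C(=O)c2c[nH]c3ccccc23)cc1`, the demethylated analogue, gives 47300 nM; the step of a 1.2-fold lower number from compound 1 to compound 3 (0.08 log units; within the scatter) is a change within the scatter. Compound 2 `COc1ccc2[nH]cc(C(=O)/C(C#N)=C/C=C(\Cl)c3ccc(OC)c(OC)c3)c2c1` differs from compound 1 in several places. In this assay compound 2 gives 44900 nM, a number again close to that of compound 1. All three numbers therefore sit together in a narrow band.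

Compound 4 `COc1ccc(/C(Cl)=C/C=C(\C#N)C(=O)c2c(C)[nH]c3ccccc23)cc1OC` differs from compound 1 by methoxy in place of hydrogen on an aromatic carbon. Within the data shown here, no measured pair covers exactly this change. Among the measured compounds shown here, the only single-point step available, from compound 1 to compound 3, was within the scatter, and compound 2, which carries the same pair of methoxy groups as compound 4 but on a different core, does not separate from compound 1 either. There is thus no ground in these numbers to expect a step beyond the scatter in this assay for compound 4 in either direction. Compound 4 is expected to give about 50000 nM, with a range of 25000 nM to 100000 nM, meaning an expected step of a 1.1-fold lower number from compound 1 to compound 4 (0.05 log units; within the scatter).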

Compound 4, concentration for 50% growth inhibition: 29600 nM
Compound 4: the middle estimate sits 1.7-fold (0.23 log units) above what was measured; the range from low to high includes it.
By their numbers in this assay, from the lowest: compounds 4, 2, 3 and 1 (each within the scatter of the next).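

In this assay, methoxy in place of hydrogen on an aromatic carbon, ortho to a methoxy group and meta to a large group, gives a 1.9-fold lower number from compound 1 to compound 4 (0.28 log units; within the scatter) and so stays inside the usual spread of repeats. Within the data shown here, this is the first direct reading of this position, and it shows that this single change on the core of compound 1 does not separate the pair. No measurement at hand bears on the size of this step.

From the compounds shown here alone, it remains open whether an amine, a carboxylic acid or a longer alkoxy chain at this place would give a step beyond the scatter. Going by these compounds, it is also open whether the same methoxy change would give a similar step on the core of compound 3, which has hydrogen in place of the methyl.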